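This account rests on a few compounds, and the source may have more. Where it says the series, first, only, none or still open, it means among the compounds named here.

Of the compounds shown here, three have been measured in an assay on isolated protein for inhibition of alkaline phosphatase, tissue-nonspecific isozyme (Homo sapiens); on this read-out lower numbers stand for stronger inhibition and higher numbers for weaker inhibition. Compound 1 `COc1ccc(C#N)cc1S(=O)(=O)Nc1cnc2ccccc2c1` gives 38 nM, compound 3 `COc1ccc(C(F)(F)F)cc1S(=O)(=O)Nc1cnc2ccccc2c1` gives 26 nM, and compound 2 `COc1ccc(Cl)cc1S(=O)(=O)Nc1cncc(-c2ccc(Cl)cc2)c1` gives 198 nM. Compound 2 thus has the highest number of the three, and its gaps to compound 1 and to compound 3 both lie beyond the scatter. For the measured compounds named here, the one step known between two compounds differing in a single place is a 1.5-fold lower number from compound 1 to compound 3 (0.16 log units; within the scatter), a swap of trifluoromethyl for cyano on an aromatic carbon of the shared core.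

Compound 4 `COc1ccc(Cl)cc1S(=O)(=O)Nc1cncc(-c2ccc(C)cc2)c1` differs from compound 2 in one place: methyl in place of chloro on an aromatic carbon, that is, 4-chlorophenyl to 4-methylphenyl. Going by the values given here, no measured step touches this ring or this pair of groups, and the only step known, from compound 1 to compound 3, stayed within the scatter. There is therefore no ground to expect a change beyond the scatter, in either direction. The expected step is a 1.0-fold higher number from compound 2 to compound 4 (0.00 log units; within the scatter). Compound 4 is accordingly estimated at 200 nM, with a range from 80 nM to 500 nM.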

Compound 4, half-maximal inhibitory concentration: 147 nM
The estimate for compound 4 lay 1.4-fold (0.13 log units) above the measured number; low and high end bracket the measured number.
By their numbers in this assay, from the lowest: compounds 3 and 1 (each within the scatter of the next); then compounds 4 and 2 (each within the scatter of the next).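

In this assay, the swap of 4-chlorophenyl to 4-methylphenyl gives a 1.3-fold lower number from compound 2 to compound 4 (0.13 log units; within the scatter) and so stays within the scatter. For the compounds shown here, this is the first look at this position, on an aromatic carbon para to a large group, and it shows that chloro and methyl, each a single heavy atom, cannot be told apart here on this read-out. No separate measurement bears on why the two groups read alike.

What the compounds shown leave open is whether this position accepts other groups equally well, for instance an amine, a carboxylic acid or a longer chain in place of the methyl. Going by these compounds alone, also open is whether the same swap would read alike on another core, as only this one pair carries it.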